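Double-bond configuration: from compound 3 to compound 4

The compounds below may be only part of what the source reports. "The series", "measured", "known", "first", "only" and "open" are said of these compounds alone.

compound 1 `COc1cc(/C=C/c2ccc3c(ccn3S(=O)(=O)c3ccccc3)c2)cc(OC)c1OC` gives > 5000 nM (a limit)
compound 2 `COc1cc(/C=C\c2ccc3c(ccn3S(=O)(=O)c3ccccc3)c2)cc(OC)c1OC` gives > 5000 nM (a limit)
compound 3 `COc1cc(/C=C/c2ccc3[nH]ccc3c2)cc(OC)c1OC` gives 470 nM

For the measured compounds named here, in a functional assay on A549 cells (Homo sapiens) for inhibition (a higher number here means a weaker inhibitor, a lower number a stronger inhibitor), compound 3 holds the only actual number, and the other two values are limits. The compound still to be read is compound 4 `COc1cc(/C=C\c2ccc3[nH]ccc3c2)cc(OC)c1OC`. The change to it is this: the two compounds have the same atoms and bonds and differ only in configuration as drawn: 1 of 1 stereo elements differ; a double bond is drawn E in compound 3 and Z in compound 4. The atoms and bonds stay the same, and only the drawn configuration of the double bond differs.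

The same kind of change has one precedent, a step that the two limits leave unreadable from compound 1 to compound 2, and its size is hidden by the limit of > 5000 nM in this assay, at which 2 of the 3 values shown sit. The other measured step, an at least 10-fold lower number from compound 1 to compound 3 (1.02 log units; beyond the scatter), is large, but it is hydrogen in place of phenylsulfonyl on an aromatic nitrogen, and that hydrogen stays in place in the step at hand. It therefore sets no size for a change of configuration.

The measured steps fix no direction, so only a tentative expectation is possible, with a wide range that also covers no change. The expected step is a 3.1-fold lower number from compound 3 to compound 4 (0.50 log units; beyond the scatter), toward a lower number. The estimate for compound 4 is 150 nM, with an expected range of 25 nM to 1500 nM.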

Compound 4, half-maximal inhibitory concentration: 390 nM
Compound 4: middle estimate off by 2.6-fold (0.41 log units), on the low side; low and high end bracket the measured number.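

In this assay, the change of double-bond configuration now has a readable step where the aromatic nitrogen carries hydrogen: a 1.2-fold lower number from compound 3 to compound 4 (0.08 log units; within the scatter), so the E and Z forms are not separated on this pair. Hydrogen in place of phenylsulfonyl on the aromatic nitrogen now also has a reading on the Z pair, an at least 12-fold lower number from compound 2 to compound 4 (1.10 log units; beyond the scatter), and the change is large with either drawn configuration: the same change on two cores in this assay, an at least 10-fold lower number (1.02 log units; beyond the scatter) from compound 1 to compound 3 and an at least 12-fold lower number (1.10 log units; beyond the scatter) from compound 2 to compound 4; the limit leaves it open whether they differ. The configuration step with phenylsulfonyl on the nitrogen still cannot be read, as compound 1 and compound 2 both sit at a limit: the limit of > 5000 nM in this assay, at which 2 of the 4 values shown sit.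

The compounds shown leave open whether configuration matters at all once a group other than hydrogen sits on that nitrogen. They also leave open how a smaller group there, such as methyl or acetyl, would read in this assay.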